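This account rests on a few compounds, and the source may have more. Where it says the series, first, only, none or still open, it means among the compounds named here.

Measured in a functional assay on A549 cells (Homo sapiens) for antiproliferative activity, read by CCK-8 assay, with a stated time of 72 h; a lower number here means a stronger inhibitor, a higher number a weaker inhibitor:
compound 1 `COc1ccccc1C(=O)Nc1cccc(-c2oc3cc(-c4ccc(F)cc4)ccc3c(=O)c2O)c1` gives 11700 nM
compound 2 `O=C(Nc1cccc(-c2oc3cc(-c4ccc(F)cc4)ccc3c(=O)c2O)c1)c1ccc(Br)cc1` gives 13500 nM
compound 3 `Cc1cc(C)cc(C(=O)Nc2cccc(-c3oc4cc(-c5ccc(F)cc5)ccc4c(=O)c3O)c2)c1` gives 3740 nM

Among these three numbers compound 1 stands second highest. Its nearest neighbour is compound 2, with a 1.2-fold higher number from compound 1 to compound 2 (0.06 log units; within the scatter); its furthest is compound 3, with a 3.1-fold lower number from compound 1 to compound 3 (0.50 log units; beyond the scatter). The next compound to consider is compound 4 `O=C(Nc1cccc(-c2oc3cc(-c4ccc(F)cc4)ccc3c(=O)c2O)c1)c1cc(F)cc(F)c1`. Relative to compound 1 the change is 3,5-difluorophenyl in place of 2-methoxyphenyl on a carbonyl carbon.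

For the measured compounds named here, two measured steps bear on this. Swapping the 2-methoxyphenyl for a 4-bromophenyl left the number essentially unchanged, whereas swapping it for a 3,5-dimethylphenyl gave a modest improvement. A 3,5-difluorophenyl is therefore expected to give a modest step toward a lower number, a 2.0-fold lower number from compound 1 to compound 4 (0.29 log units; within the scatter), though a smaller step than compound 3 showed is possible. For compound 4 the estimate is 6000 nM, with a likely range from 2500 nM to 14000 nM.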

Compound 4, half-maximal inhibitory concentration: 7620 nM
Beside the measured number, compound 4's estimate is 1.3-fold (0.10 log units) below it, within the range that was stated.
By their numbers in this assay, from the lowest: compound 3; then compounds 4, 1 and 2 (each within the scatter of the next).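

Against the 2-methoxyphenyl the 3,5-difluorophenyl gives a 1.5-fold lower number from compound 1 to compound 4 (0.19 log units; within the scatter) and against the 4-bromophenyl it gives a 1.8-fold lower number from compound 2 to compound 4 (0.25 log units; within the scatter) so neither swap moves the number past the usual scatter. The 3,5-dimethylphenyl alone stands apart, with a 2.0-fold higher number from compound 3 to compound 4 (0.31 log units; beyond the scatter) and this shows that the 3,5-dimethylphenyl and 3,5-difluorophenyl are not interchangeable on this carbonyl carbon. No measurement at hand accounts for that gap.

Still open, on these data alone, is how an amine or a carboxylic acid on this aromatic ring would change the number. A longer chain in place of the ring is equally untested among the compounds shown.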